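The compounds below may be only part of what the source reports. "The series", "measured", "known", "first", "only" and "open" are said of these compounds alone.

Compound 2, `O=C1CC(c2nc(-c3ccc(F)cc3)no2)CN1c1ccc(Cl)cc1`, is examined in an in vitro functional assay on HEK293-A cells for positive allosteric modulation of metabotropic glutamate receptor 5 (Homo sapiens), read by FLIPR and calcium flux (on this read-out higher numbers stand for an effect only at larger amounts of compound and lower numbers for an effect already at smaller amounts), together with compound 1, `Cc1cccc(-c2noc(C3CC(=O)N(c4ccc(C)c(Cl)c4)C3)n2)c1`. In this assay compound 2 gives 1700 nM, the larger of the two numbers available, while compound 1 gives 240 nM; the gap between these two values lies beyond the usual scatter, so compound 2 stands as the weaker of the pair on this read-out. Among the measured compounds shown here, the two compounds differ at more than one place, and no single step between them is recorded.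

Compound 3, `COc1cccc(-c2noc(C3CC(=O)N(c4ccc(Cl)cc4)C3)n2)c1`, is the next compound to be measured. It differs from compound 2 in one place: 3-methoxyphenyl in place of 4-fluorophenyl on an aromatic carbon, on an aromatic carbon of the five-membered aromatic ring with two nitrogen and one oxygen. With only compound 2 as a direct point of reference, the expectation for compound 3 rests on it alone. Compound 3 is expected to give a somewhat lower number in this assay than compound 2, with a step of a 2.1-fold lower number from compound 2 to compound 3 (0.33 log units; beyond the scatter) anticipated. For compound 3 the estimated value in this assay is 800 nM, with a plausible range from 250 nM to 2500 nM.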

Compound 3, half-maximal effective concentration: 4800 nM
The estimate for compound 3 lay 6.0-fold (0.78 log units) below the measured number; measured number above the stated range.
By their numbers in this assay, from the lowest: compound 1; then compound 2; then compound 3.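

Among the compounds shown here, replacing 4-fluorophenyl with 3-methoxyphenyl on the aromatic carbon between two ring nitrogen atoms gives a 2.8-fold higher number from compound 2 to compound 3 (0.45 log units; beyond the scatter) in this assay and is the first comparison here in which only one place changes, showing that this position responds to the choice of aryl group while the rest of the molecule stays the same. The direction is toward an effect only at larger amounts of compound, but the change combines two differences: the substituent on the phenyl ring is not the same, and neither is its place on that ring, so this single step cannot separate them. Nothing available bears on the reason for the step, and no cause can be assigned to it.

The compounds shown leave open how 3-fluorophenyl or 4-methoxyphenyl would stand at this carbon, which would tell the effect of the group from the effect of its place on the phenyl ring. They also leave open whether an unsubstituted phenyl or a phenyl bearing an amine would follow the same direction, and whether this step would hold with a different group on the core.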